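Benzyl for tert-butyl on the shared core

A few compounds are considered here, and "the series" means these few. Any claim that something is new, unique, unknown or untested is made for them only; others in the source may bear on it.

Measured compounds:
compound 1 `C=CCn1ncc2c(C)nc(C(C)C)n2c1=O` — > 48000 nM
compound 2 `C=CCn1ncc2c(C)nc(C(C)(C)C)n2c1=O` — > 48000 nM

In a functional assay for inhibition, with Homo sapiens as the target (on this read-out lower numbers stand for stronger inhibition and higher numbers for weaker inhibition), compound 1 gives only a limit of the assay, > 48000 nM. Compound 2 likewise gives only a limit of the assay, > 48000 nM. The step that the two limits leave unreadable from compound 1 to compound 2 cannot be read because both values sit at the limit of > 48000 nM in this assay, at which 2 of the 2 values shown sit. Compound 2 therefore stands at the limit of this assay and nowhere else on the numbers shown; no measured number places it.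

Compound 3 `C=CCn1ncc2c(C)nc(Cc3ccccc3)n2c1=O` differs from compound 2 by benzyl in place of tert-butyl on an aromatic carbon. Among the measured compounds shown here, the only measured step is the one from compound 1 to compound 2, and it is unreadable, so no size of step in this assay is taken from it. On that basis compound 3 is expected to remain at or near the limit, with a value estimated at 60000 nM (15000 nM to 250000 nM). The step that the limit leaves unreadable from compound 2 to compound 3 is expected to stay within the scatter, most likely reported again as a limit.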

Compound 3, half-maximal inhibitory concentration: > 48000 nM
Compound 3 was reported as a limit; the forecaster's own chance of this, stated with the estimate: 80%; the middle value lies beyond the limit too.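

In this assay no new step can be read among compound 1, compound 2 and compound 3, because all three values are limits: the limit of > 48000 nM in this assay, at which 3 of the 3 values shown sit. The compounds shown leave open whether any group on this aromatic carbon of the shared core gives a measurable value.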